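This account rests on a few compounds, and the source may have more. Where it says the series, first, only, none or still open, it means among the compounds named here.

- Compound 1 `Cc1cc(N2CC[C@@H](C)[C@@H](N(C)c3ncnc4[nH]ccc34)C2)n2ncnc2n1`: 11300 nM
- Compound 2 `Cc1cc(N2CC[C@@H](C)[C@@H](N(C)c3ncnc4[nH]ccc34)C2)n2nc(SCc3csc4ccc(Cl)cc34)nc2n1`: > 100000 nM
- Compound 3 `Cc1cc(N2CC[C@@H](C)[C@@H](N(C)c3ncnc4[nH]ccc34)C2)n2nc(SCc3ccc(F)cc3)nc2n1`: 26000 nM

These values come from a functional assay on HGC-27 cells (Homo sapiens) for inhibition, read by MTT assay, with a stated time of 72 h; a lower number here means a stronger inhibitor, a higher number a weaker inhibitor. The entry for compound 2 is a limit of the assay, not a number. Of the two actual numbers, the higher belongs to compound 3, a weak inhibitor at 26000 nM.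

Compound 4 `Cc1cc(N2CC[C@@H](C)[C@@H](N(C)c3ncnc4[nH]ccc34)C2)n2nc(SCc3cc(Cl)ccc3Cl)nc2n1` carries 2,5-dichlorophenyl in place of 4-fluorophenyl on a saturated chain carbon bound to a sulfur.

Going by the values given here, three measured steps bear on this. Adding a sulfanyl side chain raised the number both times: a 2.3-fold higher number from compound 1 to compound 3 (0.36 log units; beyond the scatter) and an at least 8.8-fold higher number from compound 1 to compound 2 (0.94 log units; beyond the scatter). Exchanging the aryl group also mattered: an at least 3.8-fold lower number from compound 2 to compound 3 (0.58 log units; beyond the scatter). The chlorinated group of compound 2 therefore suggests a modest rise, and the expected change is a 2.1-fold higher number from compound 3 to compound 4 (0.33 log units; beyond the scatter). For compound 4 the estimated value is 55000 nM, with an expected range of 20000 nM to 100000 nM.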

Compound 4, half-maximal inhibitory concentration: 19200 nM
The estimate for compound 4 lay 2.9-fold (0.46 log units) above the measured number, outside the stated range (below it).
By their numbers in this assay, from the lowest: compounds 1, 4 and 3 (each within the scatter of the next, the first and the last beyond it). At a limit, above all of these: compound 2.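

Exchanging the aryl group on this side chain gives a 1.4-fold lower number from compound 3 to compound 4 (0.13 log units; within the scatter), so 4-fluorophenyl and 2,5-dichlorophenyl cannot be told apart here. Compound 4 also cannot be told apart from the unsubstituted compound, with a 1.7-fold higher number from compound 1 to compound 4 (0.23 log units; within the scatter), whereas the side chain of compound 3 did give a step beyond the scatter. Chlorine on the aryl group therefore does not by itself go with the poor result of compound 2, with an at least 5.2-fold lower number from compound 2 to compound 4 (0.71 log units; beyond the scatter), a step that starts from a limit and not a number: the limit of > 100000 nM in this assay, at which 1 of the 4 values shown sits.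

Still open, going by these compounds, is whether any side chain at this place can bring the number below that of compound 1. An amine or a carboxylic acid on the benzyl ring, or a longer chain after the sulfur, could test this.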